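Series notes: from compound 3 to compound 4

The compounds below may be only part of what the source reports. "The series", "measured", "known", "first", "only" and "open" are said of these compounds alone.

Of the compounds shown here, three on a shared core have been measured in an ADME assay on Li23 cells (Homo sapiens) for cytotoxicity, read by WST assay; a higher number here means that more compound is tolerated, a lower number that less compound is tolerated. Compound 1 `Cc1ccc(C(=O)N(C)c2ccc(C(O)(C(F)(F)F)C(F)(F)F)cc2)cc1` gives 26000 nM, compound 2 `CN(C(=O)C1CCCCC1)c1ccc(C(O)(C(F)(F)F)C(F)(F)F)cc1` gives 20000 nM, and compound 3 `CN(c1ccc(C(O)(C(F)(F)F)C(F)(F)F)cc1)S(=O)(=O)c1ccccc1` gives 16000 nM. Compound 3 carries the lowest of the three numbers as written, but the steps of a 1.6-fold lower number from compound 1 to compound 3 (0.21 log units; within the scatter) and a 1.3-fold lower number from compound 2 to compound 3 (0.10 log units; within the scatter) both lie within the scatter, as does a 1.3-fold lower number from compound 1 to compound 2 (0.11 log units; within the scatter), so no separation among the three can be read from these numbers.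

Compound 4 `Cc1cccc(S(=O)(=O)N(C)c2ccc(C(O)(C(F)(F)F)C(F)(F)F)cc2)c1` has not yet been measured. It differs from compound 3 by methyl in place of hydrogen on an aromatic carbon. Among the measured compounds shown here, none of the measured steps places a methyl on an aromatic carbon of the phenylsulfonyl group; the nearest precedents are the exchanges of whole groups on the nitrogen, each of which left this assay within the scatter. On that basis no step beyond the scatter is expected here either. Compound 4 is expected to give 16000 nM in this assay, with a range of 8000 nM to 32000 nM, which means an expected step of no change at the digits printed from compound 3 to compound 4 (within the scatter) within the scatter.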

Compound 4, half-maximal cytotoxic concentration: 11000 nM
Compound 4: middle estimate off by 1.5-fold (0.16 log units), on the high side; the measured number falls inside the stated range.
By their numbers in this assay, from the lowest: compounds 4, 3, 2 and 1 (each within the scatter of the next, the first and the last beyond it).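

Methyl in place of hydrogen on an aromatic carbon, meta to a large group, is the only step among these compounds confined to one carbon of the phenylsulfonyl group, and in this assay it gives a 1.5-fold lower number from compound 3 to compound 4 (0.16 log units; within the scatter) without separating the pair. Phenyl to 3-methylphenyl thus joins the whole-group exchanges on the nitrogen, as every listed step in the series remains within the scatter. No evidence is available that bears on this result.

From the compounds shown here alone, whether an amine, a carboxylic acid or a longer chain at this same place would also stay within the scatter remains open. Methyl at other places on this ring is also unresolved, and so is whether any single-place change on the shared core can produce a step beyond the scatter in this assay at all.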